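A few compounds are considered here, and "the series" means these few. Any claim that something is new, unique, unknown or untested is made for them only; others in the source may bear on it.

Measured in a physicochemical assay for lipophilicity, measured as octanol-water partition, at pH 7.4; a lower number here means a more polar compound, a higher number a more lipophilic compound:
compound 1 `Cc1csc(C(=O)N[C@H]2CN(S(=O)(=O)c3ccccc3)C[C@@H]2C(=O)N[C@H]2CCCNC2)n1`: 0.1
compound 2 `O=C(N[C@H]1CN(S(=O)(=O)c2ccccc2)C[C@@H]1C(=O)N[C@H]1CCCNC1)c1cn(C2CC2)cn1`: -0.7
compound 3 `O=C(N[C@H]1CN(S(=O)(=O)c2ccccc2)C[C@@H]1C(=O)N[C@H]1CCCNC1)c1cc(-c2ccccc2Cl)on1`: 1.9

Compound 3 stands highest of the three. Compound 4 `CC(=O)N1CCC[C@H](NC(=O)[C@H]2CN(S(=O)(=O)c3ccccc3)C[C@@H]2NC(=O)c2cc(-c3ccccc3Cl)on2)C1` differs from it by acetyl in place of hydrogen on an amine nitrogen in a ring. The measured steps are a number 0.80 log units lower from compound 1 to compound 2 (beyond the scatter) (modest), a number 1.80 log units higher from compound 1 to compound 3 (beyond the scatter) (large) and a number 2.60 log units higher from compound 2 to compound 3 (beyond the scatter) (large). All three change the group on a carbonyl carbon, so none tests this place, and the expectation rests on the structural change alone. In this assay a modest upward step is expected, a number 0.70 log units higher from compound 3 to compound 4 (beyond the scatter), with wide uncertainty. Compound 4 is estimated at 2.6, with an expected range from 2 to 3.2.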

Compound 4, distribution coefficient: 3.5
Compound 4: the middle estimate sits 0.90 log units below what was measured, and the stated range ends below it.
By their numbers in this assay, from the lowest: compound 2; then compound 1; then compound 3; then compound 4.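

In this assay, acetyl in place of hydrogen on the amine nitrogen in the six-membered ring gives a number 1.60 log units higher from compound 3 to compound 4 (beyond the scatter). Among the compounds shown here, this is the first reading at this nitrogen, as the earlier steps all changed the group on a carbonyl carbon, and capping it moves the number upward. Nothing measured here accounts for the step.

As far as these compounds go, the change is read only with the group on the carbonyl carbon of compound 3, so its size with the groups of compound 1 or compound 2 stays open. From the compounds shown here alone, how a methyl group or a longer acyl chain on this nitrogen would compare also remains open.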